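Nitro position on the aryl ring of the thiosemicarbazone

This account rests on a few compounds, and the source may have more. Where it says the series, first, only, none or still open, it means among the compounds named here.

Compound 3 `CC1=CC[C@@H]([C@@](C)(O)CCCC(C)(C)NC(=S)N/N=C\c2ccccc2[N+](=O)[O-])CC1` sits at the bottom of the series: in a functional assay on PCO3 cells (Homo sapiens) for cytotoxicity, read by sulforhodamine B assay (on this read-out higher numbers stand for weaker inhibition of growth and lower numbers for stronger inhibition of growth), compound 3 gives > 100000 nM, which is a limit of the assay and not a number (the limit of > 100000 nM in this assay, at which 1 of the 3 values shown sits). Compound 1 `CC1=CC[C@@H]([C@@](C)(O)CCCC(C)(C)NC(=S)N/N=C\c2ccc(C)cc2)CC1` gives 45700 nM and compound 2 `CC1=CC[C@@H]([C@@](C)(O)CCCC(C)(C)NC(=S)N/N=C\c2ccc(O)cc2)CC1` gives 13900 nM. The steps into compound 3 were an at least 2.1-fold higher number from compound 1 to compound 3 (0.34 log units; beyond the scatter) and an at least 7.1-fold higher number from compound 2 to compound 3 (0.85 log units; beyond the scatter). Compound 4 `CC1=CC[C@@H]([C@@](C)(O)CCCC(C)(C)NC(=S)N/N=C\c2ccc([N+](=O)[O-])cc2)CC1` differs from compound 3 only in the ring: 4-nitrophenyl in place of 2-nitrophenyl on a carbon with a double bond to nitrogen. Among the measured compounds shown here, no measured step compares 4-nitrophenyl with 2-nitrophenyl; the two compounds carrying a 4-substituted ring, compound 1 and compound 2, both give numbers within range. A step towards lower numbers, an at least 2.5-fold lower number from compound 3 to compound 4 (0.39 log units; beyond the scatter), is therefore expected. Compound 4 is estimated at 40000 nM, with a range from 12000 nM to 130000 nM.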

Compound 4, concentration for total growth inhibition: > 100000 nM
Compound 4: no number, only a limit; the forecaster's own chance of this, stated with the estimate: 30%; at least 2.5-fold (0.39 log units) between middle value and limit.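

In this assay compound 4 gives > 100000 nM, which is a limit of the assay and not a number. Compound 3 and compound 4 therefore both stand at the limit, so the step between them cannot be read and the two nitro positions cannot be ranked: the limit of > 100000 nM in this assay, at which 2 of the 4 values shown sit.

A 4-substituted ring alone does not keep a number within range, since nitro on the aromatic carbon gives an at least 7.1-fold higher number from compound 2 to compound 4 (0.85 log units; beyond the scatter) and an at least 2.1-fold higher number from compound 1 to compound 4 (0.34 log units; beyond the scatter).

From the compounds shown here alone, whether an amine or a methoxy group on that aromatic carbon would give a number within range remains open. Also open, going by these compounds, is whether compound 3 and compound 4 differ at all.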